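Ester Side Chain Replaced by Isopropyl: Expectation for Compound 3

A few compounds are considered here, and "the series" means these few. Any claim that something is new, unique, unknown or untested is made for them only; others in the source may bear on it.

Compound 1 `COC(=O)CCNC(=O)Cn1cc(C2=C(c3c[nH]c4ccccc34)C(=O)N(C)C2=O)c2ccccc21`: 28400 nM
Compound 2 `COC(=O)CC[C@@H](NC(=O)Cn1cc(C2=C(c3c[nH]c4ccccc34)C(=O)N(C)C2=O)c2ccccc21)C(=O)OC`: 47400 nM

In a functional assay on Bel-7402 cells (Homo sapiens) for cytotoxicity, read by MTT assay, with a stated time of 24 h (a lower number here means a stronger inhibitor, a higher number a weaker inhibitor), compound 1 gives 28400 nM, and compound 2 gives 47400 nM. Within the data shown here, compound 2 stands alongside compound 1 as the only other measured compound, with the step of a 1.7-fold higher number from compound 1 to compound 2 (0.22 log units; within the scatter) lying within the scatter. Compound 3 `COC(=O)[C@@H](CC(C)C)NC(=O)Cn1cc(C2=C(c3c[nH]c4ccccc34)C(=O)N(C)C2=O)c2ccccc21` carries isopropyl in place of (methoxycarbonyl)methyl on a saturated chain carbon, two bonds along the chain from an amide-type nitrogen and a carbonyl carbon. Among the measured compounds shown here, the sole measured step touching this side chain, a 1.7-fold higher number from compound 1 to compound 2 (0.22 log units; within the scatter), stayed within the scatter, so no movement beyond the scatter is expected in this assay. The step the estimate means, a 1.4-fold lower number from compound 2 to compound 3 (0.13 log units; within the scatter), is expected to remain within the scatter. Compound 3 is therefore estimated at 35000 nM, in the range 12000 nM to 100000 nM.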

Compound 3, half-maximal inhibitory concentration: 42400 nM
Compound 3: middle estimate off by 1.2-fold (0.08 log units), on the low side; the measured number falls inside the stated range.
By their numbers in this assay, from the lowest: compounds 1, 3 and 2 (each within the scatter of the next).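

In this assay, isopropyl in place of (methoxycarbonyl)methyl on this saturated chain carbon gives a 1.1-fold lower number from compound 2 to compound 3 (0.05 log units; within the scatter) and so shows that a side chain without that ester group stays within the scatter. The larger swap of 2-(methoxycarbonyl)ethyl for 1-(methoxycarbonyl)-3-methylbutyl on the amide-type nitrogen gives a 1.5-fold higher number from compound 1 to compound 3 (0.17 log units; within the scatter) and also stays within it. No evidence available here accounts for these results. From the compounds shown here alone, whether an amine, a carboxylic acid or a longer chain at this carbon would take the number beyond the scatter remains open.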